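Benzyloxy substituent variation on the shared core; compound 3 outlook

The source may hold more compounds than are shown below. What is called first, only, known or untested is meant among the compounds shown, and "the series" means these compounds.

Compound 1 `COc1cc(OC)c(-c2coc3cc(OCc4ccc(Br)cc4)ccc3c2=O)cc1OC` gives 1000 nM in a functional assay on A-375 cells (Homo sapiens) for antiproliferative activity, read by MTT assay, with a stated time of 24 h; a lower number here means a stronger inhibitor, a higher number a weaker inhibitor. Compound 2 `COc1cc(OC)c(-c2coc3cc(OCc4ccc(C#N)cc4)ccc3c2=O)cc1OC` gives 1550 nM, the higher of the two numbers shown, yet within the scatter of compound 1 after the step of a 1.6-fold higher number from compound 1 to compound 2 (0.19 log units; within the scatter). Compound 3 `COc1cc(OC)c(-c2coc3cc(OCc4ccccc4Br)ccc3c2=O)cc1OC` differs from compound 2 by 2-bromophenyl in place of 4-cyanophenyl on a saturated chain carbon bound to an oxygen on an aromatic ring. Among the compounds with values here, only the step from compound 1 to compound 2 bears on this change, and it stayed within the scatter; no measured pair carries 2-bromophenyl. Compound 3 is therefore expected to remain close to compound 2, the step estimated as a 1.3-fold lower number from compound 2 to compound 3 (0.11 log units; within the scatter). Compound 3 is estimated at 1200 nM, range 500 nM to 3000 nM.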

Compound 3, half-maximal inhibitory concentration: 2850 nM
Beside the measured number, compound 3's estimate is 2.4-fold (0.38 log units) below it; measured number inside the range.
By their numbers in this assay, from the lowest: compounds 1, 2 and 3 (each within the scatter of the next, the first and the last beyond it).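

Moving the bromine from 4-bromophenyl to 2-bromophenyl on the same saturated chain carbon gives a 2.9-fold higher number from compound 1 to compound 3 (0.45 log units; beyond the scatter), the first step in this series at this position to pass beyond the scatter, though only modestly. The change from 4-cyanophenyl to 2-bromophenyl, a 1.8-fold higher number from compound 2 to compound 3 (0.26 log units; within the scatter), stays within it, so the clearer contrast is between the two bromine-bearing groups. No supporting data explain this step.

Still open, as far as these compounds go, is whether 2-cyanophenyl would follow 2-bromophenyl on this carbon. Also open, from the compounds shown here alone, is how an unsubstituted phenyl or a carboxylic acid on that ring would compare.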